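This account rests on a few compounds, and the source may have more. Where it says the series, first, only, none or still open, it means among the compounds named here.

Measured in a functional assay on Shh Light II cells (Mus musculus) for inhibition, read by a luciferase reporter; on this read-out higher numbers stand for weaker inhibition and lower numbers for stronger inhibition:
- compound 1 `O=C(NC1CCS(=O)(=O)CC1)N1CCC(c2nc(-c3ccc4ccccc4n3)no2)CC1`: 360 nM
- compound 2 `Cn1c(-c2noc(C3CCN(C(=O)NC4CCCCC4)CC3)n2)nc2ccccc21`: 89 nM
- compound 3 `O=C(NC1CC[S+]([O-])CC1)N1CCC(c2nc(-c3ccc4ccccc4n3)no2)CC1`: 850 nM

Compound 2 has the lowest number of the three, and its gaps to both others lie beyond the scatter. The next compound, compound 4 `Cn1c(-c2noc(C3CCN(C(=O)NC4CCS(=O)(=O)CC4)CC3)n2)nc2ccccc21`, keeps the core of compound 2 and changes one group: 1,1-dioxothian-4-yl in place of cyclohexyl on an amide-type nitrogen. For the measured compounds named here, no measured pair makes this exact change.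

Going by the values given here, the only measured step at this place is a 2.4-fold higher number from compound 1 to compound 3 (0.37 log units; beyond the scatter). It is modest, but it does not start from cyclohexyl and it sits on another core, so it bears only indirectly. Compound 1 carries 1,1-dioxothian-4-yl and gives 360 nM, while compound 2 gives 89 nM, but their cores differ as well, so that gap cannot be assigned to the group alone. A modest rise in the number in this assay is therefore expected, with low confidence. The expected step is a 2.1-fold higher number from compound 2 to compound 4 (0.33 log units; beyond the scatter). For compound 4 the estimated value is 190 nM, with an expected range of 60 nM to 600 nM.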

Compound 4, half-maximal inhibitory concentration: 350 nM
The estimate for compound 4 lay 1.8-fold (0.27 log units) below the measured number; the range from low to high includes it.
By their numbers in this assay, from the lowest: compound 2; then compounds 4 and 1 (each within the scatter of the next); then compound 3.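

On the core of compound 2, the change from cyclohexyl to 1,1-dioxothian-4-yl on an amide-type nitrogen can now be read directly: a 3.9-fold higher number from compound 2 to compound 4 (0.59 log units; beyond the scatter) in this assay. With 1,1-dioxothian-4-yl held fixed, 1-methyl-1H-benzimidazol-2-yl in place of quinolin-2-yl gives a 1.0-fold lower number from compound 1 to compound 4 (0.01 log units; within the scatter), so the two cores do not separate with this group on the amide-type nitrogen, even though compound 2 keeps the lowest number of the series. No evidence is available on what lies behind the step from cyclohexyl to 1,1-dioxothian-4-yl.

Still open, from the compounds shown here alone, is whether a cyclohexyl group on the core of compound 1 would read differently from compound 2. Also open, going by these compounds, is how a 4-hydroxycyclohexyl, a tetrahydropyran-4-yl or a piperidin-4-yl group would fall at this position.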